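Ethyl ester in place of free acid: compound 3 to compound 4

The source may report more compounds than this note shows. Statements on the series, on what has been measured and on what is new or still open speak of the compounds shown alone.

Measured so far in an assay on CHO cells for displacement of a labelled ligand from adenosine receptor A3 (Homo sapiens); a higher number here means a weaker inhibitor, a lower number a stronger inhibitor:
compound 1 `OCc1cnn(-c2nc(Nc3ccc(C(F)(F)F)cc3)c3ncn([C@@H]4O[C@H](CO)[C@@H](O)[C@H]4O)c3n2)c1` gives 15 nM
compound 2 `CCOC(=O)c1cnn(-c2nc(NC3CCCCC3)c3ncn([C@@H]4O[C@H](CO)[C@@H](O)[C@H]4O)c3n2)c1` gives 30 nM
compound 3 `O=C(O)c1cnn(-c2nc(NC34CCC(CC3)C4)c3ncn([C@@H]4O[C@H](CO)[C@@H](O)[C@H]4O)c3n2)c1` gives > 5000 nM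

The value of compound 3 is a limit of this assay and not a number. Compound 3 sits at the limit of > 5000 nM in this assay, at which 1 of the 3 values shown sits. Compound 1 and compound 2 both return numbers inside the measurable range.

Compound 4 `CCOC(=O)c1cnn(-c2nc(NC34CCC(CC3)C4)c3ncn([C@@H]4O[C@H](CO)[C@@H](O)[C@H]4O)c3n2)c1` has not yet been measured. It differs from compound 3 by ethyl in place of hydrogen on an oxygen next to a carbonyl group. Within the data shown here, compound 2 also carries the ethoxycarbonyl group and in this assay compound 2 gives 30 nM, though it differs from compound 4 in the amine, so no step between compound 2 and compound 4 can be counted.

Among the measured compounds shown here, no step between measured compounds is available for this change. Still, a large move toward lower numbers, well beyond the scatter, is expected: an at least 83-fold lower number from compound 3 to compound 4 (1.92 log units; beyond the scatter). Compound 4 is therefore estimated at 60 nM, with a range from 10 nM to 400 nM.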

Compound 4, inhibition constant: 250 nM
For compound 4 the middle estimate is 4.2-fold (0.62 log units) below the measured one, within the range that was stated.
By their numbers in this assay, from the lowest: compounds 1 and 2 (each within the scatter of the next); then compound 4. At a limit, above all of these: compound 3.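

In this assay, changing 4-carboxy-1H-pyrazol-1-yl to 4-(ethoxycarbonyl)-1H-pyrazol-1-yl with the amine held fixed gives an at least 20-fold lower number from compound 3 to compound 4 (1.30 log units; beyond the scatter). Compound 3 stands at a limit and not at a number, so the full size of this step cannot be read: the limit of > 5000 nM in this assay, at which 1 of the 4 values shown sits. With the ethoxycarbonyl group held fixed, the amine also matters, with an 8.3-fold higher number from compound 2 to compound 4 (0.92 log units; beyond the scatter).

Open, going by these compounds, is how a methyl ester, a longer-chain ester or a primary amide would compare with the ethyl ester at this place. Also open, on these data alone, is whether the step from carboxylic acid to ethyl ester keeps its size with other amines.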